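A few compounds are considered here, and "the series" means these few. Any claim that something is new, unique, unknown or untested is made for them only; others in the source may bear on it.

Measured compounds:
compound 1, `CCCCCCOC(=O)CCC(=O)N1CCN(CCCOc2cc3c(Nc4ccc(F)c(Cl)c4)ncnc3cc2OC)CC1`, 85.1%;
compound 2, `CCCCCCCOC(=O)CCC(=O)N1CCN(CCCOc2cc3c(Nc4ccc(F)c(Cl)c4)ncnc3cc2OC)CC1`, 79.9%;
compound 3, `CCCCCCCCCCCCCCCCCCCOC(=O)CCC(=O)N1CCN(CCCOc2cc3c(Nc4ccc(F)c(Cl)c4)ncnc3cc2OC)CC1`, 94.8%.

All three were tested in a functional assay on A549 cells (Homo sapiens) for cytotoxicity, read by MTT assay, with a stated time of 24 h, tested at 20 uM; a higher number here means a weaker effect of the compound at the concentration tested, a lower number a stronger effect. The change from compound 1 to compound 2, (methyl in place of hydrogen on a saturated chain carbon, six bonds along the chain from an oxygen next to a carbonyl group), gave a number 5.2 percentage points lower from compound 1 to compound 2 (within the scatter). The further change gave a number 14.9 percentage points higher from compound 2 to compound 3 (beyond the scatter). Compound 4, `CCCCCCCCCCCCCCCCCCCCOC(=O)CCC(=O)N1CCN(CCCOc2cc3c(Nc4ccc(F)c(Cl)c4)ncnc3cc2OC)CC1`, has not been measured. It differs from compound 3 by methyl in place of hydrogen on a saturated chain carbon, ten or more bonds along the chain from an oxygen next to a carbonyl group, the same kind of change as in the first pair, though at a different place along the chain. The difference between the cores of compound 1 and compound 3 is not broken down here. A step of a number 1.8 percentage points lower from compound 3 to compound 4 (within the scatter) is expected, because the same kind of change gave only a number 5.2 percentage points lower from compound 1 to compound 2 (within the scatter). Compound 4 is estimated at 93%, between 82% and 100%.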

Compound 4, a percentage reported as activity, at one concentration (the size of the read-out at that concentration, not a potency): 90.8%
The estimate for compound 4 lay 2.2 percentage points above the measured number; the range from low to high includes it.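

In this assay, methyl in place of hydrogen on a saturated chain carbon gave a number 4 percentage points lower from compound 3 to compound 4 (within the scatter), and the earlier step on the other core agrees with it: the same change on two cores in this assay, a number 5.2 percentage points lower (within the scatter) from compound 1 to compound 2 and a number 4 percentage points lower (within the scatter) from compound 3 to compound 4, 1.2 percentage points apart, within the scatter of two such steps.
This shows that the change carried from one core to the other without a difference that can be told from scatter. Among the compounds shown here, since neither step lies beyond the scatter, it shows only that the change did little on both cores, not that it has a reliable effect of any particular size, and two pairs say nothing about other cores.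

The compounds shown leave open whether the same would hold for a branched chain, or for a chain ending in an amine or a carboxylic acid. They also leave open how an amide in place of the ester would behave.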